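Sulfonylurea series: open-chain dialkylamino in place of pyrrolidinyl

The compounds below may be only part of what the source reports. "The series", "measured", "known", "first", "only" and "open" are said of these compounds alone.

Three sulfonylureas on a shared core have been measured in an assay on liver for inhibition of sterol O-acyltransferase 1 (Rattus norvegicus), using microsomes; on this read-out higher numbers stand for weaker inhibition and lower numbers for stronger inhibition. Compound 1 `CC(C)NS(=O)(=O)NC(=O)Nc1c(C(C)C)cccc1C(C)C` gives 18000 nM, compound 2 `CC(C)c1cccc(C(C)C)c1NC(=O)NS(=O)(=O)N1CCCC1` gives 15000 nM and compound 3 `C=CCN(CC)S(=O)(=O)NC(=O)Nc1c(C(C)C)cccc1C(C)C` gives 2100 nM. Compound 2 thus sits second highest of the three numbers: the nearer step is a 1.2-fold lower number from compound 1 to compound 2 (0.08 log units; within the scatter), whereas the gap to compound 3 is a 7.1-fold lower number from compound 2 to compound 3 (0.85 log units; beyond the scatter).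

Compound 4 `CCCCN(CC)S(=O)(=O)NC(=O)Nc1c(C(C)C)cccc1C(C)C` is not yet measured. Its change from compound 2 is butyl(ethyl)amino in place of pyrrolidin-1-yl on a sulfonyl sulfur.

For the measured compounds named here, two measured steps bear on this. Replacing pyrrolidin-1-yl by allyl(ethyl)amino gave a 7.1-fold lower number from compound 2 to compound 3 (0.85 log units; beyond the scatter), and replacing isopropylamino by allyl(ethyl)amino gave an 8.6-fold lower number from compound 1 to compound 3 (0.93 log units; beyond the scatter); both point the same way and both lie beyond the scatter. Butyl(ethyl)amino, like allyl(ethyl)amino, is an open-chain group with an ethyl on the nitrogen, so in this assay a step of similar direction is expected for compound 4, toward a lower number, though no measured step tells whether butyl behaves as allyl does. Compound 4 is therefore estimated at 3000 nM, with a range from 1000 nM to 9000 nM, which would mean an expected step of a 5.0-fold lower number from compound 2 to compound 4 (0.70 log units; beyond the scatter).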

Compound 4, half-maximal inhibitory concentration: 1200 nM
Beside the measured number, compound 4's estimate is 2.5-fold (0.40 log units) above it; the measured number falls inside the stated range.
By their numbers in this assay, from the lowest: compounds 4 and 3 (each within the scatter of the next); then compounds 2 and 1 (each within the scatter of the next).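

In this assay, butyl(ethyl)amino on the sulfonyl sulfur gives (a 13-fold lower number from compound 2 to compound 4 (1.10 log units; beyond the scatter)) against pyrrolidin-1-yl and (a 15-fold lower number from compound 1 to compound 4 (1.18 log units; beyond the scatter)) against isopropylamino, both beyond the scatter and both large, so the drop seen with compound 3 is no longer the result of a single open-chain group. At this position, propyl in place of vinyl on a saturated chain carbon bound to a sulfonamide nitrogen gives (a 1.8-fold lower number from compound 3 to compound 4 (0.24 log units; within the scatter)), which lies within the scatter, so the butyl and allyl chains cannot be told apart here, and the unsaturated chain end of compound 3 is not required for a number in this range. No supporting measurement is at hand to explain these steps.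

Pyrrolidin-1-yl and butyl(ethyl)amino differ both in the ring and in the heavy-atom count, so a larger ring such as piperidin-1-yl or azepan-1-yl would be needed to separate the two changes. From the compounds shown here alone, it also remains open whether the ethyl on the nitrogen matters and how far the chain can grow, which diethylamino, dibutylamino or hexyl(ethyl)amino would address.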